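Swapping an azetidine for an ethoxy group on the benzamide

This account rests on a few compounds, and the source may have more. Where it says the series, first, only, none or still open, it means among the compounds named here.

Compound 3 `CS(=O)(=O)Nc1ccc(CNC(=O)c2ccc(N3CCC3)cc2)c(Cl)c1` is the weakest of the three measured compounds in an assay on HeLa cells for agonist activity at Bile acid receptor (Homo sapiens), read by a luciferase reporter, with a stated time of 24 h (a higher number here means that more compound is needed for the effect, a lower number that less compound is needed), giving 13000 nM. Compound 1 `CC(C)S(=O)(=O)Nc1ccc(CNC(=O)c2ccc(C(C)(C)C)cc2)c(Cl)c1` gives 420 nM in this assay, and compound 2 `CC(C)(C)c1ccc(C(=O)NCc2ccc(NS(=O)(=O)C3CC3)cc2Cl)cc1` gives 1500 nM. Among the measured compounds shown here, the only single-point step among the measured compounds, cyclopropyl in place of isopropyl on a sulfonyl sulfur, is a 3.6-fold higher number from compound 1 to compound 2 (0.55 log units; beyond the scatter); it concerns a different part of the molecule and does not bear directly on the change considered here. Compound 4 `CCOc1ccc(C(=O)NCc2ccc(NS(C)(=O)=O)cc2Cl)cc1` differs from compound 3 by ethoxy in place of azetidin-1-yl on an aromatic carbon. Compounds 1 and 2 differ from compound 3 in more than one place, so their values only hint that other groups at this position go with lower numbers. The expected step is therefore a 2.6-fold lower number from compound 3 to compound 4 (0.41 log units; beyond the scatter), a moderate move toward a lower number, with wide uncertainty. Compound 4 is estimated at 5000 nM, within a range of 1500 nM to 15000 nM.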

Compound 4, half-maximal effective concentration: 2200 nM
The estimate for compound 4 lay 2.3-fold (0.36 log units) above the measured number; measured number inside the range.
By their numbers in this assay, from the lowest: compound 1; then compounds 2 and 4 (each within the scatter of the next); then compound 3.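

In this assay, ethoxy in place of azetidin-1-yl on this aromatic carbon gives a 5.9-fold lower number from compound 3 to compound 4 (0.77 log units; beyond the scatter), the only comparison shown at this position that changes nothing else, and it shows that the number responds to the group placed here. The two groups have the same counts of hydrogen-bond donors and acceptors and no net charge, so those counts do not separate them; they differ in that the four-membered ring gives way to an open chain and the nitrogen gives way to an oxygen. No measurement available here accounts for the step.

These compounds cannot tell whether losing the ring or exchanging the atom matters more. A dimethylamino group would keep the nitrogen without the ring, and a propyl chain would keep the open chain without the oxygen.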